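A small expected step to 3-methoxyphenyl

The compounds below may be only part of what the source reports. "The series", "measured", "known", "first", "only" and "open" are said of these compounds alone.

Compound 1 `CC(Nc1ccccc1Oc1cccc(F)c1)=C1C(=O)CC(c2ccccc2)CC1=O`: 170 nM
Compound 2 `CC(Nc1ccccc1Oc1ccc(C(C)O)cc1)=C1C(=O)CC(c2ccccc2)CC1=O`: 120 nM

In a functional assay on CCRF-CEM cells (Homo sapiens) for antiproliferative activity, read by cell counting, with a stated time of 96 h (on this read-out higher numbers stand for weaker inhibition and lower numbers for stronger inhibition), compound 2 at 120 nM has the lower of the two numbers, but it stands within the scatter of compound 1 at 170 nM. Compound 3 `COc1cccc(Oc2ccccc2NC(C)=C2C(=O)CC(c3ccccc3)CC2=O)c1` carries 3-methoxyphenyl in place of 4-(1-hydroxyethyl)phenyl on an oxygen on an aromatic ring. Within the data shown here, the only measured change at this place is a 1.4-fold lower number from compound 1 to compound 2 (0.15 log units; within the scatter). One such swap therefore offers no sign of a large effect, and no shift beyond the scatter is expected in this assay. The estimated step is a 1.3-fold higher number from compound 2 to compound 3 (0.10 log units; within the scatter). Compound 3 is expected at 150 nM, with an estimated range of 60 nM to 380 nM.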

Compound 3, half-maximal inhibitory concentration: 41 nM
For compound 3 the middle estimate is 3.7-fold (0.56 log units) above the measured one, outside the stated range (below it).
By their numbers in this assay, from the lowest: compound 3; then compounds 2 and 1 (each within the scatter of the next).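

In this assay, the group on this oxygen can clearly move the number: 3-methoxyphenyl in place of 4-(1-hydroxyethyl)phenyl gives a 2.9-fold lower number from compound 2 to compound 3 (0.47 log units; beyond the scatter) and so goes beyond the scatter, which compounds 1 and 2 alone never did. Methoxy in place of fluoro gives a 4.1-fold lower number from compound 1 to compound 3 (0.62 log units; beyond the scatter) as well, so a change of one small group on an aromatic carbon is enough for a real step. Nothing available explains either step.

From the compounds shown here alone, whether an ethoxy group, a longer chain, would extend this gain remains open. So does the effect of an amine or a carboxylic acid on the same ring.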